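The source may report more compounds than this note shows. Statements on the series, on what has been measured and on what is new or still open speak of the compounds shown alone.

Values so far in a functional assay on PC-3 cells (Homo sapiens) for cytotoxicity, read by sulforhodamine B assay, with a stated time of 72 h; on this read-out higher numbers stand for weaker inhibition of growth and lower numbers for stronger inhibition of growth
- compound 1 `O=C(Nc1ccccc1O)C1CCc2ccccc2N1C(=O)c1ccc(Cl)cc1` gives 25100 nM
- compound 2 `O=C(Nc1ccccc1O)C1CCc2ccccc2N1C(=O)c1ccccc1` gives 5690 nM

Of the two, compound 2 has the lower number at 5690 nM and serves as the reference for compound 3 `O=C(Nc1ccccc1O)C1CCc2ccccc2N1C(=O)c1cccc(Cl)c1` here. The change is chloro in place of hydrogen on an aromatic carbon with chloro in place of hydrogen on an aromatic carbon, meta to a large group. Among the measured compounds shown here, the one measured step that bears on it is a 4.4-fold lower number from compound 1 to compound 2 (0.64 log units; beyond the scatter) with hydrogen in place of chloro, though that chloro sits elsewhere. A higher number in this assay is therefore expected, of similar or smaller size. The expected move is a 1.9-fold higher number from compound 2 to compound 3 (0.29 log units; within the scatter) in this working estimate. In this assay the estimate for compound 3 is 11000 nM with an expected range of 4500 nM to 27000 nM for now.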

Compound 3, concentration for 50% growth inhibition: 23300 nM
Compound 3: the middle estimate sits 2.1-fold (0.33 log units) below what was measured; low and high end bracket the measured number.
By their numbers in this assay, from the lowest: compound 2; then compounds 3 and 1 (each within the scatter of the next).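

In this assay, chloro in place of hydrogen at the meta position also raises the number for compound 3 (a 4.1-fold higher number from compound 2 to compound 3 (0.61 log units; beyond the scatter)), so the rise seen with chloro is not confined to the earlier site. Shifting chloro from 4-chlorophenyl to 3-chlorophenyl gives no readable difference (a 1.1-fold lower number from compound 1 to compound 3 (0.03 log units; within the scatter)). No evidence on the cause is at hand.

Still open, from the compounds shown here alone, is whether a rise follows any group on this aromatic ring or is particular to chloro. A methoxy group, an amine or a carboxylic acid at these places would test that.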